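This account rests on a few compounds, and the source may have more. Where it says the series, first, only, none or still open, it means among the compounds named here.

The measured compounds:
compound 1 `O=C1NCCc2nc(C#Cc3ccccc3)sc21`, giving 112 nM in an assay on HEK293 cells for positive allosteric modulation of metabotropic glutamate receptor 5 (Homo sapiens), read by FLIPR, with a stated time of 1 h; on this read-out lower numbers stand for an effect already at smaller amounts and higher numbers for an effect only at larger amounts of compound;
compound 2 `O=C1NCCc2nc(C#Cc3cccc(F)c3)sc21`, giving 290 nM in this assay;
compound 3 `CCC(=O)N1CCc2nc(C#Cc3ccccc3)sc2C1`, for which this assay reports only the limit of > 10000 nM.

Going by the values given here, compound 3 therefore stands outside the measured numbers: what is known of it is a limit of the assay, not a value, and it is the one compound of the three to sit there (the limit of > 10000 nM in this assay, at which 1 of the 3 values shown sits). Among the compounds with numbers, a single step is measured, a 2.6-fold higher number from compound 1 to compound 2 (0.41 log units; beyond the scatter), a fluoro in place of hydrogen on an aromatic carbon; it is modest and beyond the scatter, but it concerns the aromatic ring, not the acyl group on the ring nitrogen.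

Compound 4 `O=C(C1CC(F)C1)N1CCc2nc(C#Cc3ccccc3)sc2C1` differs from compound 3 by 3-fluorocyclobutyl in place of ethyl on a carbonyl carbon. Among the compounds with values here, no measured step touches this part of the molecule, so the measured steps give no direction for it; the only anchor is compound 3 itself, which is known solely as a limit. The expectation is that compound 4 behaves in the same way, with a number no higher from compound 3 to compound 4 (the limit leaves the size open), that is no step beyond the scatter, and most likely again a limit rather than a number. On that basis compound 4 is estimated at 10000 nM, with a range from 2500 nM to 40000 nM.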

Compound 4, half-maximal effective concentration: 85 nM
The estimate for compound 4 lay 120-fold (2.07 log units) above the measured number; measured number outside the range, below it.
By their numbers in this assay, from the lowest: compounds 4 and 1 (each within the scatter of the next); then compound 2. At a limit, above all of these: compound 3.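

In this assay the group on the carbonyl carbon, itself on the amide-type nitrogen in a ring, proves to be a place where one change can bring a compound from a limit to a readable number. Going by these compounds alone, the step is an at least 110-fold lower number from compound 3 to compound 4 (2.07 log units; beyond the scatter), with 3-fluorocyclobutyl in place of ethyl, and it is far larger than the modest earlier step on the aromatic ring, the only step measured before, which said nothing about this part of the molecule. Compound 3 stays a limit of the assay and not a number, and it is the only compound shown that sits there: the limit of > 10000 nM in this assay, at which 1 of the 4 values shown sits.

What the change from ethyl to 3-fluorocyclobutyl does not separate is the share of the four-membered ring, the share of the fluorine and the share of the larger group as such, and a plain cyclobutyl, a cyclopropyl or a longer chain such as butyl on the same carbonyl carbon would bear on that. Going by these compounds, it also remains open whether a hydroxyl or an amine in place of the fluorine on the cyclobutyl ring, or a fluoro on the aromatic ring of compound 4, would keep a number of this order.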